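A few compounds are considered here, and "the series" means these few. Any claim that something is new, unique, unknown or untested is made for them only; others in the source may bear on it.

Compound 1 `O=C(Nc1nn(-c2ccccc2)c(=O)c2ccccc12)c1ccccc1` has the highest number of three compounds in an assay on CHO cells for displacement of a labelled ligand from adenosine receptor A1 (Homo sapiens), tested at 10 uM (a higher number here means more inhibition at the concentration tested (going by the name of the read-out), a lower number less inhibition), where compound 1 gives 44%. Compound 2 `O=C(Nc1ccccc1Cl)Nc1nn(-c2ccccc2)c(=O)c2ccccc12` gives 0% in this assay, and compound 3 `COc1ccc(OC)c(NC(=O)Nc2nn(-c3ccccc3)c(=O)c3ccccc23)c1` gives 0%. The step of a number 44 percentage points lower from compound 1 to compound 2 (beyond the scatter) shows that replacing the benzoyl group by a urea lowers the number in this assay, and the step of no change at the digits printed from compound 2 to compound 3 (within the scatter) shows that the number stays level across the two ureas. Compound 4 `COc1ccc(C(=O)Nc2nn(-c3ccccc3)c(=O)c3ccccc23)cc1` keeps the amide of compound 1 and differs only by methoxy in place of hydrogen on an aromatic carbon. Neither measured step touches this ring, so the data give no direct guide; the amide itself is retained, so a step of no size beyond the scatter is expected, a number 1 percentage points higher from compound 1 to compound 4 (within the scatter). Compound 4 is therefore estimated at 45%, ranging from 20% to 70%.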

Compound 4, a percentage reported as inhibition, at one concentration (the size of the read-out at that concentration, not a potency): 0%
For compound 4 the middle estimate is 45 percentage points above the measured one, outside the stated range (below it).
By their numbers in this assay, from the lowest: compounds 2, 3 and 4 (each within the scatter of the next); then compound 1.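

Methoxy in place of hydrogen on this aromatic carbon, para to a large group, gives a number 44 percentage points lower from compound 1 to compound 4 (beyond the scatter) in this assay, so keeping the amide does not by itself preserve the number. The urea and this amide also read alike, with no change at the digits printed from compound 2 to compound 4 (within the scatter), so a low number here is not confined to the ureas. No measurement available here explains this loss. Still open, on these data alone, is whether fluorine or a hydroxyl group in place of the same hydrogen would also bring the number down.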